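Aryl amide replacement in a chromone-linked series

A few compounds are considered here, and "the series" means these few. Any claim that something is new, unique, unknown or untested is made for them only; others in the source may bear on it.

Measured so far:
- compound 1, `N#Cc1ccc(C(=O)Nc2cccc(NC(=O)COc3ccc4c(=O)ccoc4c3)c2)cc1`: 123 nM
- compound 2, `O=C(COc1ccc2c(=O)ccoc2c1)Nc1cccc(NC(=O)c2ccc(OC(F)(F)F)cc2)c1`: 869 nM
- compound 3, `O=C(COc1ccc2c(=O)ccoc2c1)Nc1cccc(NC(=O)c2ccc([N+](=O)[O-])cc2)c1`: 67 nM

In an assay on isolated protein for inhibition of Rho-associated protein kinase 1 (Homo sapiens), read by scintillation counting, radiometric assay and 33P incorporation, with a stated time of 40 min, in the presence of a further agent that is not named here (on this read-out lower numbers stand for stronger inhibition and higher numbers for weaker inhibition), compound 3 gives the lowest number of the three. The step of a 1.8-fold lower number from compound 1 to compound 3 (0.26 log units; within the scatter) lies within the scatter, so compound 1 and compound 3 cannot be ordered against each other; the step of a 13-fold lower number from compound 2 to compound 3 (1.11 log units; beyond the scatter) is large and beyond the scatter, and a 7.1-fold higher number from compound 1 to compound 2 (0.85 log units; beyond the scatter) is also beyond the scatter, so compound 2 stands clearly apart from the other two.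

Compound 4, `O=C(COc1ccc2c(=O)ccoc2c1)Nc1cccc(NC(=O)c2cnc(C(F)(F)F)s2)c1`, is not yet measured. It differs from compound 3 in one place: 2-(trifluoromethyl)-1,3-thiazol-5-yl in place of 4-nitrophenyl on a carbonyl carbon. Among the compounds with values here, none of the measured steps exchanges the ring itself; all three only swap one substituent on the same six-membered ring. The closest bearing is that the fluorinated substituent gave the highest number, in a 7.1-fold higher number from compound 1 to compound 2 (0.85 log units; beyond the scatter) and a 13-fold lower number from compound 2 to compound 3 (1.11 log units; beyond the scatter), whereas nitro and cyano sat close together. Within the data shown here, a five-membered ring carrying trifluoromethyl is a further departure with no direct precedent here, so a step upward in this assay of modest to large size is expected, with wide uncertainty.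

Compound 4 is therefore estimated at 350 nM, with a range from 80 nM to 1500 nM, which would mean an expected step of a 5.2-fold higher number from compound 3 to compound 4 (0.72 log units; beyond the scatter).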

Compound 4, half-maximal inhibitory concentration: 160 nM
For compound 4 the middle estimate is 2.2-fold (0.34 log units) above the measured one; low and high end bracket the measured number.
By their numbers in this assay, from the lowest: compounds 3, 1 and 4 (each within the scatter of the next, the first and the last beyond it); then compound 2.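

In this assay the carbonyl carbon accepts an exchange of the whole aromatic ring, not only of a substituent on it: with a 1.3-fold higher number from compound 1 to compound 4 (0.11 log units; within the scatter) the 2-(trifluoromethyl)-1,3-thiazol-5-yl amide cannot be ordered against the 4-cyanophenyl amide, while a 2.4-fold higher number from compound 3 to compound 4 (0.38 log units; beyond the scatter) separates it modestly from the 4-nitrophenyl amide. A fluorinated group on the aryl amide therefore does not by itself give the high number seen with 4-(trifluoromethoxy)phenyl, as a 5.4-fold lower number from compound 2 to compound 4 (0.73 log units; beyond the scatter) shows for this one pair, and two compounds set no general rule. Nothing available here accounts for these differences.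

The compounds shown do not separate the contribution of the five-membered ring from that of its trifluoromethyl group, so it remains open how the same ring behaves bearing hydrogen, an amine or a carboxylic acid in place of trifluoromethyl, and how a six-membered ring behaves bearing trifluoromethyl. It also remains open whether these steps hold on a different core, since the core and its linking chain stay the same throughout the series shown.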